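Aryl swaps on the carbonyl carbon of the shared core

A few compounds are considered here, and "the series" means these few. Any claim that something is new, unique, unknown or untested is made for them only; others in the source may bear on it.

Three measured compounds share one core and differ only in the aryl group on the carbonyl carbon. Compound 1 `COc1cc(-c2cc(/C=C/C(=O)c3ccc(N)cc3)[nH]n2)cc(OC)c1OC` gives 2080 nM in a functional assay on A549 cells (Homo sapiens) for inhibition, read by sulforhodamine B assay, with a stated time of 48 h; a lower number here means a stronger inhibitor of growth, a higher number a weaker inhibitor of growth. Compound 2 `COc1ccc(C(=O)/C=C/c2cc(-c3cc(OC)c(OC)c(OC)c3)n[nH]2)cc1OC` gives 1860 nM in this assay, and compound 3 `COc1ccc(C(=O)/C=C/c2cc(-c3cc(OC)c(OC)c(OC)c3)n[nH]2)cc1` gives 2270 nM. Compound 3 carries the highest of the three numbers, yet every step to it stays inside the scatter: a 1.1-fold higher number from compound 1 to compound 3 (0.04 log units; within the scatter) and a 1.2-fold higher number from compound 2 to compound 3 (0.09 log units; within the scatter), so no order among the three can be read.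

Compound 4 `COc1cc(-c2cc(/C=C/C(=O)c3ccc(F)c(F)c3)[nH]n2)cc(OC)c1OC` is not yet measured. It differs from compound 3 in one place: 3,4-difluorophenyl in place of 4-methoxyphenyl on a carbonyl carbon. Among the compounds with values here, the steps that bear on this change are the three aryl swaps on the same carbonyl carbon, namely a 1.1-fold lower number from compound 1 to compound 2 (0.05 log units; within the scatter), a 1.1-fold higher number from compound 1 to compound 3 (0.04 log units; within the scatter) and a 1.2-fold higher number from compound 2 to compound 3 (0.09 log units; within the scatter); all three lie within the scatter. Within the data shown here, no measured step brings fluorine into the series, so the 3,4-difluorophenyl group itself has no precedent here. On this basis no step beyond the scatter is expected in this assay for compound 4; the expected step is a 1.0-fold higher number from compound 3 to compound 4 (0.01 log units; within the scatter). Compound 4 is therefore estimated at 2300 nM, with a range from 900 nM to 6000 nM.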

Compound 4, concentration for 50% growth inhibition: 2430 nM
Compound 4: middle estimate off by 1.1-fold (0.02 log units), on the low side; low and high end bracket the measured number.
By their numbers in this assay, from the lowest: compounds 2, 1, 3 and 4 (each within the scatter of the next).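

Within the data shown here, with a 1.1-fold higher number from compound 3 to compound 4 (0.03 log units; within the scatter) in this assay, fluorine enters the series for the first time, and the aryl group on the carbonyl carbon can now be read across a wider set of substituents: a 1.3-fold higher number from compound 2 to compound 4 (0.12 log units; within the scatter) and a 1.2-fold higher number from compound 1 to compound 4 (0.07 log units; within the scatter) are equally small steps. The group that leaves carries 1 hydrogen-bond acceptor and the group that enters carries 0 hydrogen-bond acceptors, yet the number does not move beyond the scatter, so amino, methoxy and fluorine substituents on this aryl group give no separable values across compounds 1, 2, 3 and 4, and none of the four goes against this. No supporting measurement is available to explain this lack of separation.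

The compounds shown leave open whether a carboxylic acid on this aryl ring, or a cyclohexyl group in place of the aryl group on the carbonyl carbon, would give a step beyond the scatter. They also leave open whether the trimethoxyphenyl group, held constant in all four compounds, would respond as little if replaced by an unsubstituted phenyl group.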